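From 3-hydroxybenzyl to 4-hydroxycyclohexyl in compound 3

The source may hold more compounds than are shown below. What is called first, only, known or untested is meant among the compounds shown, and "the series" means these compounds.

In an ADME assay on HEK-293T cells (Homo sapiens) for cytotoxicity, read by CCK-8 assay, with a stated time of 48 h (a lower number here means a stronger inhibitor, a higher number a weaker inhibitor), compound 1 `O=C(NCCNS(=O)(=O)c1ccc(-c2ccccc2OCc2cccc(O)c2)s1)Nc1cc(C(F)(F)F)cc(C(F)(F)F)c1` gives > 20000 nM, which is a limit of the assay and not a number. Compound 2 `COc1ccc(NC(=O)NCCNS(=O)(=O)c2sccc2-c2ccc(C)cc2Oc2ccc(O)c(O)c2)cc1` gives > 20000 nM, also a limit. Compound 3 `O=C(NCCNS(=O)(=O)c1ccc(-c2ccccc2O[C@H]2CC[C@@H](O)CC2)s1)Nc1cc(C(F)(F)F)cc(C(F)(F)F)c1` carries 4-hydroxycyclohexyl in place of 3-hydroxybenzyl on an oxygen on an aromatic ring. Among the compounds with values here, no measured step is available to size this change. Within the data shown here, the only guide from compound 1 and compound 2 is the limit of > 20000 nM in this assay, at which 2 of the 2 values shown sit. The estimated change is a step that the limit leaves unreadable from compound 1 to compound 3, with no step beyond the scatter expected. For compound 3 the expected value is 25000 nM, with an estimated range of 10000 nM to 60000 nM.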

Compound 3, half-maximal inhibitory concentration: 14100 nM
The estimate for compound 3 lay 1.8-fold (0.25 log units) above the measured number; low and high end bracket the measured number.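

In this assay, compound 3 gives the first readable number shown for the series, 14100 nM, so this oxygen on an aromatic ring tolerates 4-hydroxycyclohexyl with the read-out inside the measurable range. Replacing 3-hydroxybenzyl with 4-hydroxycyclohexyl gives an at least 1.4-fold lower number from compound 1 to compound 3 (0.15 log units; that floor lies within the scatter). On these data alone, the value of compound 1 is a limit, so the true size of this step stays unknown. As far as these compounds go, whether the hydroxyl matters at this position remains open, as does the effect of an amine or a carboxylic acid in its place on the cyclohexyl ring.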